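Working notes: a hexyl group on the saturated ring

The source may report more compounds than this note shows. Statements on the series, on what has been measured and on what is new or still open speak of the compounds shown alone.

Measured in an ADME assay on U2OS cells (Homo sapiens) for cytotoxicity; a higher number here means that more compound is tolerated, a lower number that less compound is tolerated:
Compound 1 `O=C(N/N=C/c1ccc([N+](=O)[O-])o1)c1cccs1`: 57200 nM
Compound 2 `O=C(N/N=C/c1ccc([N+](=O)[O-])o1)C1CCCCC1`: 25400 nM

Compound 2 has the lower of the two numbers. Compound 3 `CCCCCCC1CCC(C(=O)N/N=C/c2ccc([N+](=O)[O-])o2)CC1` differs from it by hexyl in place of hydrogen on a saturated ring carbon. For the measured compounds named here, the only measured step is a 2.3-fold lower number from compound 1 to compound 2 (0.35 log units; beyond the scatter), with cyclohexyl in place of thiophen-2-yl on a carbonyl carbon. That step is modest and lies at a different kind of change, so it offers weak guidance. A modest move to a lower number in this assay is expected, with a wide range. The expected change is a 2.1-fold lower number from compound 2 to compound 3 (0.33 log units; beyond the scatter). The estimate for compound 3 is 12000 nM, with an expected range of 3500 nM to 35000 nM.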

Compound 3, half-maximal cytotoxic concentration: > 200000 nM
Compound 3: only a limit was reported; the forecaster's own chance of this, stated with the estimate: 5%; at least 16-fold (1.22 log units) between middle value and limit.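

In this assay, hexyl in place of hydrogen on a saturated ring carbon gives an at least 7.8-fold higher number from compound 2 to compound 3 (0.89 log units; beyond the scatter). A change on the saturated ring can therefore raise the number, a direction that the earlier step, a 2.3-fold lower number from compound 1 to compound 2 (0.35 log units; beyond the scatter), did not show. The reading for compound 3 is a limit and not a number: the limit of > 200000 nM in this assay, at which 1 of the 3 values shown sits.

On these data alone, how far the true value of compound 3 lies past that limit remains open. Also open, as far as these compounds go, is whether a shorter chain such as butyl, or an amine, on the same ring carbon would raise the number too.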